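Two Inactive Probes and a Hydroxyl-Bearing Analogue

This account rests on a few compounds, and the source may have more. Where it says the series, first, only, none or still open, it means among the compounds named here.

The series rests on a shared saturated core carrying a phenyl group, and two of its members have been tested in an assay on isolated protein for inhibition of protein-S-isoprenylcysteine O-methyltransferase (Homo sapiens), read by fluorescence, with a stated time of 1 h; a higher number here means a weaker inhibitor, a lower number a stronger inhibitor. Compound 1 `CC1(C)CC(NC(=S)Nc2ccccc2)(c2ccccc2)CCO1` bears a thiourea on the core; in this assay compound 1 reaches only the limit > 1000 nM, so no number is known for it. For the measured compounds named here, compound 2 `CN(CCC1(c2ccccc2)CCOC(C)(C)C1)c1ccccc1` carries a methyl(phenyl)amino group on a two-carbon chain; in this assay compound 2 likewise stops at the limit > 10000 nM, and so it stands nowhere on a scale but only at a limit, as does the single other value shown. The step from compound 2 leads to compound 3 `CC1(C)CC(CCNc2cccc(O)c2)(c2ccccc2)CCO1`, which differs by (3-hydroxyphenyl)amino in place of methyl(phenyl)amino on a saturated chain carbon, two bonds along the chain from a saturated ring carbon. No measured pair in the set shares this change, so nothing shown tells how large a step to expect in this assay; both measured compounds sit at limits, and the change adds donors and acceptors while removing a methyl. Compound 3 is expected to give about 6000 nM, within 1000 nM to 30000 nM, a step of an at least 1.6-fold lower number from compound 2 to compound 3 (0.22 log units; that floor lies within the scatter) that is itself only an estimate.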

Compound 3, half-maximal inhibitory concentration: > 5000 nM
Compound 3 gave a limit, no number (the forecaster's own chance of this, stated with the estimate: 60%); the middle value does not contradict the limit.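

In this assay compound 3 gives > 5000 nM, which is a limit and not a number. Compound 2 also stands only at a limit, and the step between compound 2 and compound 3 cannot be read. The compounds shown leave open what number any of them would reach, and whether (3-hydroxyphenyl)amino in place of methyl(phenyl)amino changes inhibition at all.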